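Hydroxy for dichlorophenyl on the fused core

The source may hold more compounds than are shown below. What is called first, only, known or untested is meant among the compounds shown, and "the series" means these compounds.

Of the compounds shown here, two on the shared core have been measured in an assay for binding affinity to Neuronal acetylcholine receptor; alpha4/beta2 (Rattus norvegicus); on this read-out higher numbers stand for weaker inhibition and lower numbers for stronger inhibition. Compound 1 `Clc1ccc(-c2cnc3cc4c(cc3n2)C2CNCC4C2)c(Cl)c1` gives 88 nM in this assay. Compound 2 `Cc1ccc2cc3c(cc2n1)C1CNCC3C1` gives 0.76 nM in this assay. Among the measured compounds shown here, compound 1 thus stands at the higher of the two numbers, and the gap to compound 2 lies well beyond the scatter of repeated measurements; no single-point step between these two compounds is available, so their values are simply set side by side.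

The next compound is compound 3 `Oc1cnc2cc3c(cc2n1)C1CNCC3C1`. It differs from compound 1 by the change (hydroxy in place of 2,4-dichlorophenyl on an aromatic carbon), that is, hydroxy in place of 2,4-dichlorophenyl on an aromatic carbon. For the measured compounds named here, no comparable step on this core has been measured, so the expectation rests only on the two values above and on the size of the change. Because compound 2 reaches 0.76 nM with a small substituent on the core, a compound carrying a single heavy atom at this position is expected to move toward the lower numbers. The step of an 8.8-fold lower number from compound 1 to compound 3 (0.94 log units; beyond the scatter) is expected to be downward and beyond the scatter. For compound 3 the estimate is 10 nM, with a range from 1.5 nM to 80 nM.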

Compound 3, inhibition constant: < 6 nM
Compound 3 was reported as a limit; the forecaster's own chance of this, stated with the estimate: 5%; middle value at least 1.6-fold (0.22 log units) away from the limit.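

Replacing 2,4-dichlorophenyl with hydroxy on this aromatic carbon, next to the ring nitrogen, gives an at least 14-fold lower number from compound 1 to compound 3 (1.16 log units; beyond the scatter), the only step among the compounds shown that changes one place, and it shows that the substituent here has a large effect on the number in this assay. The value of compound 3, < 6 nM, is a limit of the assay and not a number. The step therefore gives a minimum size rather than a measured size, and how far compound 3 extends toward lower numbers stays unknown: the limit of < 6 nM in this assay, at which 1 of the 3 values shown sits.

The single change removes 8 heavy atoms with their carbon ring and brings in 1 heavy atom carrying a hydrogen-bond donor and acceptor, so the compounds shown do not separate the loss of 2,4-dichlorophenyl from the arrival of hydroxy. From the compounds shown here alone, whether the lower number depends on the hydroxy group itself or only on the absence of the large aryl group stays open, and an amine, a methoxy group or an unsubstituted phenyl on this same carbon would bear on that question.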